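The source may report more compounds than this note shows. Statements on the series, on what has been measured and on what is new or still open speak of the compounds shown alone.

Among the measured compounds shown here, compound 3 `CC1CCN(c2c(S(=O)(=O)c3cccc(F)c3)cnc3ccc(Cl)cc23)CC1` stands at the bottom of the three compounds measured so far: in an assay on isolated protein for displacement of a labelled ligand from metabotropic glutamate receptor 5 (Homo sapiens), with a stated time of 60 min, tested at 1 uM (on this read-out higher numbers stand for more inhibition at the one concentration tested (going by the name of the read-out) and lower numbers for less inhibition), compound 3 gives 58%. Compound 2 `CC1CCN(c2c(S(=O)(=O)c3ccc(F)c(F)c3)cnc3ccc(Cl)cc23)CC1` gives 72% in this assay, and compound 1 `COc1cccc(S(=O)(=O)c2cnc3ccc(Cl)cc3c2N2CCC(C)CC2)c1` gives 87%. The steps among them are a number 29 percentage points lower from compound 1 to compound 3 (beyond the scatter), a number 15 percentage points lower from compound 1 to compound 2 (beyond the scatter) and a number 14 percentage points lower from compound 2 to compound 3 (beyond the scatter).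

Compound 4 `CC1CCN(c2c(S(=O)(=O)c3cccc(C#N)c3)cnc3ccc(Cl)cc23)CC1` differs from compound 3 by cyano in place of fluoro on an aromatic carbon. All three measured steps concern the same ring of the sulfonyl substituent, and every change away from 3-fluorophenyl has so far gone upward, by between the sizes seen in a number 14 percentage points lower from compound 2 to compound 3 (beyond the scatter) and a number 29 percentage points lower from compound 1 to compound 3 (beyond the scatter). For the measured compounds named here, no measured step involves cyano, so the direction rests only on that pattern. A modest upward step, a number 14 percentage points higher from compound 3 to compound 4 (beyond the scatter), is therefore expected, with the outcome uncertain.

For compound 4 in this assay, an estimated value of 72% is expected, within a range from 50% to 90%.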

Compound 4, a percentage reported as inhibition, at one concentration (the size of the read-out at that concentration, not a potency): 90%
Estimate against measurement, compound 4: 18 percentage points below, within the range that was stated.
By their numbers in this assay, from the lowest: compound 3; then compound 2; then compounds 1 and 4 (each within the scatter of the next).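

In this assay, putting cyano in place of fluoro on this aromatic carbon, meta to a large group, gives a step of large size (a number 32 percentage points higher from compound 3 to compound 4 (beyond the scatter)), and the 3-cyanophenyl group also stands apart from the 3,4-difluorophenyl group (a number 18 percentage points higher from compound 2 to compound 4 (beyond the scatter)). Methoxy and cyano, two quite different groups at this place, cannot be told apart (a number 3 percentage points higher from compound 1 to compound 4 (within the scatter)), so the read-out does not single out one group here, while fluoro alone gives a clearly lower number. Nothing measured here explains why these groups differ as they do.

Going by these compounds, it stays open how an amine, a carboxylic acid or a longer chain such as propoxy would behave at this place. On these data alone, each number also comes from one concentration, so how the compounds differ in potency remains unknown.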